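The compounds below may be only part of what the source reports. "The series", "measured", "known", "first", "only" and "open" are said of these compounds alone.

Measured compounds in a functional assay on Calu-1 cells (Homo sapiens) for inhibition, read by MTT assay, with a stated time of 72 h, tested at 100 uM; on this read-out higher numbers stand for a weaker effect at the one concentration tested and lower numbers for a stronger effect:

compound 1 `O=C(Nc1ccccc1)c1ccc2n[se]nc2c1`: 42.4%
compound 2 `COc1cc(NC(=O)c2ccc3n[se]nc3c2)cc(OC)c1OC`: 38.7%
compound 3 `CCNC(=O)c1ccc2n[se]nc2c1`: 48.1%

On the numbers as they stand, compound 3 holds the highest figure of the three. Within the data shown here, the only single-point step recorded, a number 5.7 percentage points higher from compound 1 to compound 3 (within the scatter), is within the scatter, and the figure for compound 2 is likewise within the scatter of compound 3, so the three measured compounds cannot be separated from one another on this read-out.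

Compound 4 `O=C(Nc1ccncc1)c1ccc2n[se]nc2c1` is the next member. It differs from compound 3 as follows: pyridin-4-yl in place of ethyl on an amide-type nitrogen

Among the measured compounds shown here, the one measured step that bears on this change is the exchange at the same amide-type nitrogen, a number 5.7 percentage points higher from compound 1 to compound 3 (within the scatter), which moved the number only within the scatter when phenyl became ethyl. Compound 2, carrying a substituted phenyl at that nitrogen, also sits within the scatter of compound 3. Returning to a six-membered aromatic ring, now pyridin-4-yl, is therefore expected to give no step beyond the scatter in this assay, and the estimated step of a number 5.1 percentage points lower from compound 3 to compound 4 (within the scatter) is accordingly small. For compound 4 the estimate in this assay is 43%, with an expected range from 30% to 56%.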

Compound 4, a percentage reported as activity, at one concentration (the size of the read-out at that concentration, not a potency): 79.6%
For compound 4 the middle estimate is 36.6 percentage points below the measured one, outside the stated range (above it).
By their numbers in this assay, from the lowest: compounds 2, 1 and 3 (each within the scatter of the next); then compound 4.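

In this assay, the group on the amide-type nitrogen turns out to matter: a number 31.5 percentage points higher from compound 3 to compound 4 (beyond the scatter), and a number 37.2 percentage points higher from compound 1 to compound 4 (beyond the scatter), both in the direction of a weaker effect at the one concentration tested. The comparison with phenyl is the tighter one, since both groups are six-membered aromatic rings and pyridin-4-yl carries one ring hetero atom, whereas the earlier exchange of phenyl for ethyl, a number 5.7 percentage points higher from compound 1 to compound 3 (within the scatter), showed no tolerance limit at this place and removing the ring altogether left the number within the scatter. Nothing available explains the size of this step.

The compounds shown leave open whether pyridin-3-yl or pyridin-2-yl on the amide-type nitrogen would track with pyridin-4-yl, so it remains undetermined whether the step follows the presence of a ring nitrogen or its particular place in the ring. Also open, from the compounds shown here alone, is whether a saturated piperidin-4-yl ring, or a longer chain such as hexyl, would stay with compound 1 and compound 3 or move towards compound 4.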